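Chloro to pyrrolidinylcarbonyl on the shared core

The compounds below may be only part of what the source reports. "The series", "measured", "known", "first", "only" and "open" are said of these compounds alone.

Compound 1 `CN1CCC[C@H]1COc1cncc(Cl)c1` is examined in an assay on membranes from brain for displacement of a labelled ligand from Neuronal acetylcholine receptor; alpha4/beta2 (Rattus norvegicus) (a lower number here means a stronger inhibitor, a higher number a weaker inhibitor), where compound 1 gives 0.6 nM, the highest of the three numbers shown. Compound 2 `CC(C)Cc1cncc(OC[C@@H]2CCCN2C)c1` gives 0.21 nM, and compound 3 `CCCCCCc1cncc(OC[C@@H]2CCCN2C)c1` gives 0.32 nM. The step of a 2.9-fold lower number from compound 1 to compound 2 (0.46 log units; beyond the scatter) came with isobutyl in place of chloro on an aromatic carbon, while a 1.9-fold lower number from compound 1 to compound 3 (0.27 log units; within the scatter) came with hexyl in place of chloro, and a 1.5-fold higher number from compound 2 to compound 3 (0.18 log units; within the scatter) separates the two chains. Compound 4 `CN1CCC[C@H]1COc1cncc(C(=O)N2CCCC2)c1` carries (pyrrolidin-1-yl)carbonyl in place of chloro on an aromatic carbon. The measured steps show that exchanging chloro for isobutyl or hexyl lowers the number modestly or within the scatter; none of them tests a carbonyl-bearing group at that place. Compound 4 is therefore expected to show a 3.3-fold higher number from compound 1 to compound 4 (0.52 log units; beyond the scatter). For compound 4 the estimate is 2 nM, with a range from 0.4 nM to 10 nM.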

Compound 4, inhibition constant: 19.9 nM
Compound 4: middle estimate off by 10-fold (1.00 log units), on the low side, outside the stated range (above it).
By their numbers in this assay, from the lowest: compounds 2, 3 and 1 (each within the scatter of the next, the first and the last beyond it); then compound 4.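

The position two atoms from the ring nitrogen does not accept every group alike: isobutyl and hexyl in place of chloro gave at most a modest step, whereas (pyrrolidin-1-yl)carbonyl gives a large one (a 33-fold higher number from compound 1 to compound 4 (1.52 log units; beyond the scatter)). The steps from the two chains are also large (a 62-fold higher number from compound 3 to compound 4 (1.79 log units; beyond the scatter); a 95-fold higher number from compound 2 to compound 4 (1.98 log units; beyond the scatter)). Nothing shown accounts for this rise.

The compounds shown leave open whether the rise goes with the carbonyl or with the pyrrolidine ring. A dimethylamide or a pyrrolidin-1-ylmethyl group at this place would help separate the two.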